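This account rests on a few compounds, and the source may have more. Where it says the series, first, only, none or still open, it means among the compounds named here.

Of the compounds shown here, two built on one shared core have so far been measured in a functional assay (trachea) with Rattus norvegicus as the target; on this read-out lower numbers stand for lower potency and higher numbers for higher potency (the scale is a negative logarithm). Compound 1 `CCC(=O)c1ccc2c(c1)C(n1ccccc1=O)=CC(C)(C)O2` gives 5.85 in this assay, and compound 2 `CC1(C)C=C(n2ccccc2=O)c2cc(C(=O)c3ccccc3)ccc2O1` gives 6.21. Among the measured compounds shown here, the single measured step between them, a number 0.36 log units higher from compound 1 to compound 2 (beyond the scatter), concerns only the group on the carbonyl carbon. For the measured compounds named here, compound 2 thus stands at the higher of the two numbers, with compound 1 as its only neighbour below it.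

Compound 3 `COc1ccc(C(=O)c2ccc3c(c2)C(n2ccccc2=O)=CC(C)(C)O3)cc1` differs from compound 2 in one place: methoxy in place of hydrogen on an aromatic carbon. Going by the values given here, no measured step bears directly on this change, since the step from compound 1 to compound 2 exchanged the whole group on the carbonyl carbon rather than altering the phenyl itself; the only guidance is that a change at that end of the molecule moved this assay by a modest amount. A small shift is therefore expected, probably within the usual scatter, with a slight lean upward.

For compound 3 the value in this assay is estimated at 6.3, within the range 5.7 to 6.9. That estimate means an expected step of a number 0.09 log units higher from compound 2 to compound 3 (within the scatter).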

Compound 3, logarithm of the reciprocal of the active concentration, log(1/C): 5.72
Compound 3: the middle estimate sits 0.58 log units above what was measured; low and high end bracket the measured number.
By their numbers in this assay, from the lowest: compounds 3 and 1 (each within the scatter of the next); then compound 2.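

In this assay, the phenyl ring on the carbonyl carbon proves sensitive to substitution: methoxy in place of hydrogen on an aromatic carbon, para to a large group, gives a number 0.49 log units lower from compound 2 to compound 3 (beyond the scatter). So the earlier exchange of ethyl for phenyl did not open a place where added atoms go unnoticed, and even a single small group on this ring can move the read-out beyond the scatter. Set against the ethyl ketone, 4-methoxyphenyl gives a number 0.13 log units lower from compound 1 to compound 3 (within the scatter), which leaves compound 1 and compound 3 indistinguishable in this read-out, while nothing available explains the effect of the methoxy group.

The compounds shown leave open whether this drop is specific to methoxy or would also appear with a fluorine, a methyl or an amine on the same ring carbon, and whether methoxy on a different carbon of that ring would behave alike. They also leave open how a longer chain or a benzyl group on the carbonyl carbon would compare with ethyl and phenyl.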